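Thiol amide series: methyl to cyclohexyl on the core

The source may report more compounds than this note shows. Statements on the series, on what has been measured and on what is new or still open speak of the compounds shown alone.

Measured so far:
compound 1 `Cc1cc(C(=O)NCCCCCCS)[nH]n1` — "not determined" (no result reported) in an assay on isolated protein for inhibition of protein deacetylase HDAC6 (Homo sapiens), read by fluorescence, with stated times of 15 min and 60 min; on this read-out higher numbers stand for weaker inhibition and lower numbers for stronger inhibition
compound 2 `O=C(NCCCCCCS)c1cc(-c2ccc3ccccc3c2)n[nH]1` — 235 nM

Compound 1 stands on no number: in this assay compound 1 gives "not determined" (no result reported), so nothing places it. Compound 2 in this assay gives 235 nM, the only measured point here. Compound 3 `O=C(NCCCCCCS)c1cc(C2CCCCC2)n[nH]1` differs from compound 1 by cyclohexyl in place of methyl on an aromatic carbon. Within the data shown here, no measured pair shows what this change does, so the size and direction of the step from compound 1 are open; compound 2, which carries a large group at the same place, is the only guide. Compound 3 is expected near 350 nM, with a range from 90 nM to 1400 nM.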

Compound 3, half-maximal inhibitory concentration: 241 nM
For compound 3 the middle estimate is 1.5-fold (0.16 log units) above the measured one, within the range that was stated.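

In this assay, among these compounds, compound 1 gives "not determined" (no result reported), and no step from compound 1 to compound 3 can be read. The compounds shown leave open what cyclohexyl in place of methyl does to inhibition. No evidence bears on this result.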